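Para substituent on the benzylamide of a tert-butylbenzamide series

The compounds below may be only part of what the source reports. "The series", "measured", "known", "first", "only" and "open" are said of these compounds alone.

Measured so far in an assay on HeLa cells with Bile acid receptor (Homo sapiens) as the target, read by a luciferase reporter, with a stated time of 24 h; on this read-out higher numbers stand for an effect only at larger amounts of compound and lower numbers for an effect already at smaller amounts:
compound 1 `CC(C)(C)c1ccc(C(=O)NCc2ccc(C(N)=O)cc2)cc1`, 3800 nM
compound 2 `CSc1ccc(CNC(=O)c2ccc(C(C)(C)C)cc2)cc1`, 100 nM
compound 3 `CC(C)(C)c1ccc(C(=O)NCc2ccc(OC(F)(F)F)cc2)cc1`, 160 nM

Compound 3 stands second highest of the three numbers; its nearest neighbour is compound 2, with a 1.6-fold higher number from compound 2 to compound 3 (0.20 log units; within the scatter), and its furthest is compound 1, with a 24-fold lower number from compound 1 to compound 3 (1.38 log units; beyond the scatter). The change now considered is sulfamoyl in place of trifluoromethoxy on an aromatic carbon, giving compound 4 `CC(C)(C)c1ccc(C(=O)NCc2ccc(S(N)(=O)=O)cc2)cc1`, not yet measured.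

For the measured compounds named here, no measured step carries a sulfamoyl group, so the bearing steps are indirect. Compound 1 carries a carbamoyl group at this position, and the two steps away from it, a 38-fold lower number from compound 1 to compound 2 (1.58 log units; beyond the scatter) and a 24-fold lower number from compound 1 to compound 3 (1.38 log units; beyond the scatter), were both large. The sulfamoyl group that enters brings one hydrogen-bond donor and two acceptors, closer in this respect to the carbamoyl of compound 1 than to the trifluoromethoxy it replaces. On that basis a step upward in this assay is expected, likely large, bringing compound 4 toward the number of compound 1, though the absence of a direct measurement of sulfamoyl leaves the size uncertain.

For compound 4 the estimate in this assay is 2500 nM, with a range of 600 nM to 9000 nM, corresponding to an expected step of a 16-fold higher number from compound 3 to compound 4 (1.19 log units; beyond the scatter).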

Compound 4, half-maximal effective concentration: 1400 nM
Beside the measured number, compound 4's estimate is 1.8-fold (0.25 log units) above it; measured number inside the range.
By their numbers in this assay, from the lowest: compounds 2 and 3 (each within the scatter of the next); then compound 4; then compound 1.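

In this assay, sulfamoyl on this aromatic carbon, para to a large group, gives a number that falls between the earlier levels: the change brings an 8.8-fold higher number from compound 3 to compound 4 (0.94 log units; beyond the scatter) and a 14-fold higher number from compound 2 to compound 4 (1.15 log units; beyond the scatter) yet still leaves a 2.7-fold lower number from compound 1 to compound 4 (0.43 log units; beyond the scatter) as the step from the carbamoyl compound. Across the four compounds, the sulfamoyl and carbamoyl groups both stand at higher numbers than methylsulfanyl and trifluoromethoxy, with no compound going against this order, but the two groups at the higher end are not interchangeable, as the gap between them lies beyond the scatter. Nothing available gives a reason for this order or for the gap between sulfamoyl and carbamoyl.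

An amine, a carboxylic acid or a methylsulfonyl group at this position would show whether the higher numbers extend beyond sulfamoyl and carbamoyl, and a longer chain in place of methylsulfanyl would show how far the low numbers of compound 2 and compound 3 reach. As far as these compounds go, whether the same order holds with another group in place of the tert-butyl group also stays open.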